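Swapping Methyl for Fluoro on Two Weakly Active Cores

A few compounds are considered here, and "the series" means these few. Any claim that something is new, unique, unknown or untested is made for them only; others in the source may bear on it.

Compound 1 `COc1ncc(-c2ccc3c(c2)N(c2ccc(C)cc2)C(=O)CO3)cc1NS(=O)(=O)c1ccc(F)cc1` and compound 2 `COc1ncc(-c2ccc3c(c2)N(c2ccc(F)cc2)C(=O)CO3)cc1NS(=O)(=O)c1ccc(F)cc1` share one core, while compound 3 `Cc1ccc(N2C(=O)COc3ccc(-c4cccc(NS(=O)(=O)c5ccc(F)cc5)c4)cc32)cc1` and compound 4 `O=C1COc2ccc(-c3cccc(NS(=O)(=O)c4ccc(F)cc4)c3)cc2N1c1ccc(F)cc1` share another; the difference between the two cores is not broken down here.

In a functional assay on HCT-116 cells (Homo sapiens) for antiproliferative activity, read by MTT assay, with a stated time of 72 h (on this read-out lower numbers stand for stronger inhibition and higher numbers for weaker inhibition), compound 1 gives 22700 nM. Compound 2 reaches only > 40000 nM, which is a limit of the assay rather than a number. The change fluoro in place of methyl on an aromatic carbon therefore produced an at least 1.7-fold higher number from compound 1 to compound 2 (0.24 log units; that floor lies within the scatter), with the caveat that the limit of > 40000 nM in this assay, at which 1 of the 3 values shown sits, caps what can be seen.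

For the measured compounds named here, on the second core, compound 3 gives 35600 nM in this assay, a value that sits within the usual scatter of the one for compound 1.

Compound 4 carries the change (fluoro in place of methyl on an aromatic carbon), the same change as before, at a place described in the same words. The step of an at least 1.7-fold higher number from compound 1 to compound 2 (0.24 log units; that floor lies within the scatter) is expected to repeat as a 1.7-fold higher number from compound 3 to compound 4 (0.23 log units; within the scatter), and since compound 3 already starts close to the ceiling of the assay, a limit rather than a number seems the more likely outcome. Compound 4 is thus estimated at 60000 nM, between 30000 nM and 120000 nM.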

Compound 4, half-maximal inhibitory concentration: > 40000 nM
Compound 4: a limit, no number; the forecaster's own chance of this, stated with the estimate: 70%; the middle value does not contradict the limit.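

In this assay compound 4 gives > 40000 nM, which is a limit of the assay and not a number. Going from 4-methylphenyl to 4-fluorophenyl on the second core gives an at least 1.1-fold higher number from compound 3 to compound 4 (0.05 log units; that floor lies within the scatter), and setting this beside the first core shows a change that, on both cores, ends at the assay's limit rather than at a measurable number: the same change on two cores in this assay, an at least 1.7-fold higher number (0.24 log units; that floor lies within the scatter) from compound 1 to compound 2 and an at least 1.1-fold higher number (0.05 log units; that floor lies within the scatter) from compound 3 to compound 4; the limit leaves it open whether they differ. This does not show how large either step really is, or whether the change carries over from one core to the other with the same size, because only minimum sizes can be read and both lie within the usual scatter: the limit of > 40000 nM in this assay, at which 2 of the 4 values shown sit.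

From the compounds shown here alone, only methyl and fluoro appear at this spot, so what a methoxy group, an amine or a carboxylic acid in place of the methyl would do in this assay stays open. Also open, going by these compounds, is whether either core can give a clearly stronger result than compound 1 at 22700 nM.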